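The source may hold more compounds than are shown below. What is called first, only, known or untested is meant among the compounds shown, and "the series" means these compounds.

Measured compounds so far, in a functional assay for inhibition of sodium/hydrogen exchanger (Oryctolagus cuniculus); on this read-out lower numbers stand for stronger inhibition and higher numbers for weaker inhibition:
compound 1, `Cc1cc(Br)c(S(C)(=O)=O)cc1C(=O)N=C(N)N`, gives 12 nM
compound 2, `CCc1cc(Cl)c(S(C)(=O)=O)cc1C(=O)N=C(N)N`, gives 63 nM
compound 3, `CCc1cc(Br)c(S(C)(=O)=O)cc1C(=O)N=C(N)N`, gives 41 nM

Among these three numbers compound 3 stands second highest. Its nearest neighbour is compound 2, and the step of a 1.5-fold lower number from compound 2 to compound 3 (0.19 log units; within the scatter) lies within the scatter, so the two cannot be told apart. Its furthest neighbour is compound 1, and the step of a 3.4-fold higher number from compound 1 to compound 3 (0.53 log units; beyond the scatter) is a modest, real rise in the number, meaning weaker inhibition for compound 3.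

Compound 4, `CCN(CC)Cc1cc(Br)c(S(C)(=O)=O)cc1C(=O)N=C(N)N`, has not yet been measured. It differs from compound 3 in one place: diethylamino in place of methyl on a saturated chain carbon bound to an aromatic carbon. For the measured compounds named here, no measured pair shows this kind of change, so no step bears on it directly. Going by the values given here, the only step at the same place is a 3.4-fold higher number from compound 1 to compound 3 (0.53 log units; beyond the scatter), where lengthening the group by one carbon made the number rise. The new group is larger again and brings a hydrogen-bond acceptor, so a further shift in the same direction, or none beyond the scatter, seems the likeliest outcome, though the change is of a different kind and the uncertainty is wide. Compound 4 is therefore expected to show a 1.7-fold higher number from compound 3 to compound 4 (0.23 log units; within the scatter), with an estimated value of 70 nM in this assay, in the range 15 nM to 300 nM.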

Compound 4, half-maximal inhibitory concentration: 9500 nM
Compound 4: middle estimate off by 140-fold (2.13 log units), on the low side; the measured number lies above the stated range.
By their numbers in this assay, from the lowest: compound 1; then compounds 3 and 2 (each within the scatter of the next); then compound 4.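

For the compounds shown here, at this place, on a saturated chain carbon bound to an aromatic carbon, the earlier compounds showed only a modest sensitivity in this assay: a 3.4-fold higher number from compound 1 to compound 3 (0.53 log units; beyond the scatter). Replacing methyl with diethylamino at the same place has a far larger effect, giving a 230-fold higher number from compound 3 to compound 4 (2.36 log units; beyond the scatter), so this position accepts a one-carbon extension with a modest loss but not every larger group. Compared with the compound carrying the shortest chain, the loss is larger still, at a 790-fold higher number from compound 1 to compound 4 (2.90 log units; beyond the scatter), and no accompanying measurement offers an explanation for it.

The compounds shown leave open whether the loss follows the nitrogen of the diethylamino group or the extra heavy atoms it adds, as this is the only amine in the set and the only group of its size. A pentyl chain, which has no nitrogen, and the smaller dimethylamino group at the same place would help to separate these two readings.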